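This account rests on a few compounds, and the source may have more. Where it says the series, first, only, none or still open, it means among the compounds named here.

Compound 1 `COc1cc(CNC(=S)NCC(COC(=O)C(C)(C)C)Cc2ccc(C)c(C)c2)ccc1O` is a thiourea built on a 4-hydroxy-3-methoxybenzyl group. In a functional assay on CHO cells for antagonist activity at transient receptor potential cation channel subfamily V member 1 (Rattus norvegicus) (on this read-out higher numbers stand for weaker inhibition and lower numbers for stronger inhibition), compound 1 stands as "not evaluated" (no result reported), so there is no single number to place it against. A near relative, compound 2 `COc1cc(CNC(=S)NCC(COC(=O)C(C)(C)C)Cc2ccc(C(C)(C)C)cc2)c(I)cc1O`, which carries the iodo group and a tert-butyl group on its second aromatic ring, does have a result: in this assay compound 2 gives 71 nM. Compound 3 `COc1cc(CNC(=S)NCC(COC(=O)C(C)(C)C)Cc2ccc(C)c(C)c2)c(I)cc1O` is compound 1 with one change: iodo in place of hydrogen on an aromatic carbon. Among the compounds with values here, no measured pair shows this exact step, so its size cannot be read from the data; the only anchor is compound 2. The expectation for compound 3 in this assay is a value close to that of compound 2, because compound 2 shares the iodo group and gives 71 nM. Compound 3 is therefore estimated at 110 nM, with a plausible range from 30 nM to 450 nM.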

Compound 3, inhibition constant: 23.1 nM
Compound 3: middle estimate off by 4.8-fold (0.68 log units), on the high side; measured number below the stated range.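

With the iodo group held in both compounds, 3,4-dimethylphenyl in place of 4-(tert-butyl)phenyl gives in this assay a 3.1-fold lower number from compound 2 to compound 3 (0.49 log units; beyond the scatter), and a lower number here means stronger inhibition. The iodo compounds therefore do not all sit at one level: the group on the second aromatic ring still shifts the result by more than the usual scatter. No measurement shown here explains this shift.

Going by these compounds, compound 1 has no number in this read-out, and the size of the step from hydrogen to iodo cannot be read, so what iodo itself contributes remains unknown. Also open, on these data alone, is how chloro, bromo or an amine would compare with iodo on the same aromatic carbon, and how other groups on the second ring would compare with 3,4-dimethylphenyl.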